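This account rests on a few compounds, and the source may have more. Where it says the series, first, only, none or still open, it means among the compounds named here.

Measured in a functional assay on Jurkat cells (Homo sapiens) for cytotoxicity, read by MTT assay, with a stated time of 24 h (a lower number here means that less compound is needed, a higher number that more compound is needed for the effect), so far:
Compound 1 `CCOC(=O)c1cc([Se]Cc2ccccc2)c2cc(OC)ccc2n1` gives 20800 nM
Compound 2 `CCCCC#Cc1cc(C(=O)OCC)nc2ccc(OC)cc12` gives 15900 nM

Among the compounds with values here, compound 2 stands level with compound 1, the only other measured compound, and the step between them (a 1.3-fold lower number from compound 1 to compound 2 (0.12 log units; within the scatter)) does not separate the two. Moving on to compound 3 `CCOC(=O)c1cc([Se]c2ccc(F)cc2)c2cc(OC)ccc2n1`, the change is a group of 8 heavy atoms (6 carbon, 1 fluorine, 1 selenium; one six-membered aromatic ring of carbon only) in place of a group of 6 heavy atoms (6 carbon; no ring), on an aromatic carbon and it falls on the aromatic carbon opposite the ring nitrogen. Hex-1-yn-1-yl leaves. Like compound 1, compound 3 carries selenium and a six-membered aromatic ring of carbon only at that place, and the one measured exchange there stayed within the scatter (a 1.3-fold lower number from compound 1 to compound 2 (0.12 log units; within the scatter)). Within the data shown here, no measured compound carries fluorine, so that part of the change remains untested. No step beyond the scatter is therefore expected in this assay, and the estimated step is small (a 1.1-fold higher number from compound 2 to compound 3 (0.05 log units; within the scatter)). Compound 3 is expected at 18000 nM (estimated range 8000 nM to 40000 nM).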

Compound 3, half-maximal effective concentration: 134000 nM
Estimate against measurement, compound 3: 7.4-fold (0.87 log units) below, outside the stated range (above it).
By their numbers in this assay, from the lowest: compounds 2 and 1 (each within the scatter of the next); then compound 3.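

At the aromatic carbon opposite the ring nitrogen, the group can clearly shift the result in this assay: the selenium-linked 4-fluorophenyl group in place of hex-1-yn-1-yl gives an 8.4-fold higher number from compound 2 to compound 3 (0.93 log units; beyond the scatter). The group on selenium also matters, since 4-fluorophenyl in place of benzyl gives a 6.4-fold higher number from compound 1 to compound 3 (0.81 log units; beyond the scatter), so selenium and an aromatic ring at this place do not by themselves set the number, as the earlier exchange had left possible. No evidence on the origin of these steps is available.

The fluorine and the change from a benzyl to a phenyl ring arrive together, and the compounds shown do not tell which of them carries the step. Also open, on these data alone, is what a plain phenyl on selenium, or a carboxylic acid in place of the ethoxycarbonyl group, would give.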